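The source may hold more compounds than are shown below. What is called first, only, known or untested is meant among the compounds shown, and "the series" means these compounds.

Compound 1 `COc1ccc(C2=C(c3cc(OC)c(OC)c(OC)c3)CC3CCCN3C2=O)cc1O`: in a functional assay on SK-OV-3 cells (Homo sapiens) for cytotoxicity (on this read-out higher numbers stand for weaker inhibition of growth and lower numbers for stronger inhibition of growth), compound 1 gives > 100000 nM, a limit of the assay and not a number.
Compound 2 `COc1ccc(C2=C(c3ccc(SC)cc3)CC3CCCN3C2=O)cc1O`: in this assay compound 2 gives > 100000 nM, again a limit and not a number.

Compound 2 therefore stands at the limit of > 100000 nM in this assay, at which 2 of the 2 values shown sit, sharing that limit with compound 1, so no numbered value separates the two. Compound 3 `CSc1ccc(C2=C(c3ccc(O)c(O)c3)C(=O)N3CCCC3C2)cc1` differs from compound 2 by hydrogen in place of methyl on an oxygen on an aromatic ring. No measured step of this kind exists among these compounds. The change is expected to be small, a number no higher from compound 2 to compound 3 (the limit leaves the size open), with no direction beyond the scatter. Compound 3 is expected to give about 100000 nM in this assay, within 20000 nM to 300000 nM.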

Compound 3, concentration for 50% growth inhibition: 80000 nM
Compound 3: the middle estimate sits 1.3-fold (0.10 log units) above what was measured; the measured number falls inside the stated range.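

Compound 3 is the only one of the three to give a number rather than a limit, 80000 nM in this assay. Changing methoxy to hydroxy, which turns 3-hydroxy-4-methoxyphenyl into 3,4-dihydroxyphenyl, gives an at least 1.2-fold lower number from compound 2 to compound 3 (0.09 log units; that floor lies within the scatter). The true size of this step stays unknown, as its starting point is only a limit of the assay: the limit of > 100000 nM in this assay, at which 2 of the 3 values shown sit.

The compounds shown leave open whether a longer chain on this oxygen, or an amine in place of the hydroxy group, would move the number. They also leave open whether the same change would act alike in compound 1.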